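Compound 3 to compound 4: replacing 4-chlorophenyl

The compounds below may be only part of what the source reports. "The series", "measured", "known", "first", "only" and "open" are said of these compounds alone.

In a functional assay on A549 cells (Homo sapiens) for inhibition, read by MTT assay, with a stated time of 48 h (a higher number here means a weaker inhibitor of growth, a lower number a stronger inhibitor of growth), compound 3 (`COc1ccc2c(c1)c(C1CC(c3ccc(Cl)cc3)=NN1C(=O)c1ccc(OC)nc1)cn2C`) gives 3390 nM as the lowest number shown, and compound 1 (`Cn1cc(C2CC(c3ccccc3)=NN2C(=O)c2ccc(Cl)nc2)c2ccccc21`) gives 8460 nM as the only other number. Compound 2 (`Cn1cc(C2CC(c3ccccc3)=NN2C(=O)c2cccnc2Cl)c2ccccc21`) gives a limit (> 10000 nM) and no number.

Compound 4 (`COc1ccc2c(c1)c(C1CC(c3cc(OC)c(OC)c(OC)c3)=NN1C(=O)c1ccc(OC)nc1)cn2C`) carries 3,4,5-trimethoxyphenyl in place of 4-chlorophenyl on a carbon with a double bond to nitrogen. Going by the values given here, the single measured step (an at least 1.1-fold higher number from compound 1 to compound 2 (0.07 log units; that floor lies within the scatter)) concerns a group on a carbonyl carbon and not this place, so no measured step bears directly on the change. Also in view, on the upper side of any expectation, is the limit of > 10000 nM in this assay, at which 1 of the 3 values shown sits, in the same series.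

With no measured guide to direction, the estimated step (a 1.0-fold higher number from compound 3 to compound 4 (0.00 log units; within the scatter)) is expected to stay within the scatter in this assay and to favour neither direction. For compound 4 the estimate is 3400 nM with an expected range from 1000 nM to 10000 nM on this basis.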

Compound 4, concentration for 50% growth inhibition: > 10000 nM
Compound 4: no number, only a limit; the forecaster's own chance of this, stated with the estimate: 15%; middle value at least 2.9-fold (0.46 log units) from the limit.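

Going by these compounds alone, this is the first measured step at this place, on a carbon with a double bond to nitrogen; the earlier step concerned only a group on a carbonyl carbon. In this assay, 3,4,5-trimethoxyphenyl in place of 4-chlorophenyl gives an at least 2.9-fold higher number from compound 3 to compound 4 (0.46 log units; beyond the scatter), so the group at this place can shift growth inhibition beyond the scatter, and the size printed is only a floor. The reading for compound 4 is a limit and not a number, and it adds to the share of the series at that limit: the limit of > 10000 nM in this assay, at which 2 of the 4 values shown sit.

On these data alone, how far compound 4 lies past its limit remains open, and a single step at this place sets no trend. Also open, as far as these compounds go, is whether an amine or a carboxylic acid on the phenyl ring, in place of the chlorine of 4-chlorophenyl, would keep the reading of compound 3 or lose it.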